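The source may hold more compounds than are shown below. What is called first, only, known or untested is meant among the compounds shown, and "the series" means these compounds.

Three compounds share one core and differ only in the group on the nitrogen of the aromatic ring. Compound 1 `C#CCNc1nc(-c2ccccc2)c(Cc2c(O)ccc3ccccc23)c(=O)[nH]1` gives 148000 nM in a functional assay on EJ cells (Homo sapiens) for antiproliferative activity, read by MTT assay, with a stated time of 24 h; a higher number here means a weaker inhibitor, a lower number a stronger inhibitor. Compound 2 `O=c1[nH]c(NCCO)nc(-c2ccccc2)c1Cc1c(O)ccc2ccccc12` gives only a limit in this assay, > 300000 nM. Compound 3 `COc1ccc(Nc2nc(-c3ccccc3)c(Cc3c(O)ccc4ccccc34)c(=O)[nH]2)cc1` gives 63700 nM in this assay, the lowest of the two numbers shown, and its nearest neighbour is compound 1, with a 2.3-fold lower number from compound 1 to compound 3 (0.37 log units; beyond the scatter). Compound 4 `O=c1[nH]c(Nc2ccc(O)cc2)nc(-c2ccccc2)c1Cc1c(O)ccc2ccccc12` keeps everything of compound 3 except (hydrogen in place of methyl on an oxygen on an aromatic ring). Among the compounds with values here, no measured step touches this oxygen: the steps of an at least 2.0-fold higher number from compound 1 to compound 2 (0.30 log units; that floor lies within the scatter) and an at least 4.7-fold lower number from compound 2 to compound 3 (0.67 log units; beyond the scatter) both change the group on the nitrogen. Without a direct precedent, the change is expected to stay within the scatter, so compound 4 is expected near 55000 nM, between 20000 nM and 160000 nM, meaning a 1.2-fold lower number from compound 3 to compound 4 (0.06 log units; within the scatter).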

Compound 4, half-maximal inhibitory concentration: 92400 nM
Compound 4: middle estimate off by 1.7-fold (0.23 log units), on the low side, and the stated range covers the measured number.
By their numbers in this assay, from the lowest: compounds 3, 4 and 1 (each within the scatter of the next, the first and the last beyond it). At a limit, above all of these: compound 2.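

In this assay hydrogen in place of methyl on this oxygen gives a 1.5-fold higher number from compound 3 to compound 4 (0.16 log units; within the scatter) and so leaves the number unmoved, which means the methyl is not needed here. With the hydroxy group, the swap from propargyl gives a 1.6-fold lower number from compound 1 to compound 4 (0.20 log units; within the scatter) and stays inside the scatter, unlike the same swap with the methoxy group. The step from 2-hydroxyethyl gives an at least 3.2-fold lower number from compound 2 to compound 4 (0.51 log units; beyond the scatter) but starts from a limit: the limit of > 300000 nM in this assay, at which 1 of the 4 values shown sits.

Going by these compounds, what an ethoxy group or a longer chain on this oxygen would do stays open, as does an amine in its place.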